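Swapping a fluoro for a nitro on the anilino ring

This account rests on a few compounds, and the source may have more. Where it says the series, first, only, none or still open, it means among the compounds named here.

Of the compounds shown here, three built on one shared core have been measured in a functional assay on MGC-803 cells (Homo sapiens) for inhibition, read by MTT assay, with a stated time of 72 h; a lower number here means a stronger inhibitor, a higher number a weaker inhibitor. Compound 1 `C=CC(=O)Nc1cccc(NC(=O)CSc2nc(Nc3ccccc3)c3ccccc3n2)c1` gives 7310 nM. Compound 2 `C=CC(=O)Nc1cccc(NC(=O)CSc2nc(Nc3ccccc3Cl)c3ccccc3n2)c1` gives 20700 nM, and compound 3 `C=CC(=O)Nc1cccc(NC(=O)CSc2nc(Nc3cccc(F)c3)c3ccccc3n2)c1` gives 6250 nM. Among these three numbers compound 3 has the lowest; its nearest neighbour is compound 1, since a 1.2-fold lower number from compound 1 to compound 3 (0.07 log units; within the scatter), while its furthest is compound 2, since a 3.3-fold lower number from compound 2 to compound 3 (0.52 log units; beyond the scatter).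

Compound 4 `C=CC(=O)Nc1cccc(NC(=O)CSc2nc(Nc3cccc([N+](=O)[O-])c3)c3ccccc3n2)c1` differs from compound 3 in one place: nitro in place of fluoro on an aromatic carbon. For the measured compounds named here, no measured step exchanges a fluoro for a nitro, so the guidance is indirect. The step that adds a fluoro at this very place, a 1.2-fold lower number from compound 1 to compound 3 (0.07 log units; within the scatter), stayed within the scatter, which suggests this position tolerates a small group without much change. Going by the values given here, the only step beyond the scatter, a 2.8-fold higher number from compound 1 to compound 2 (0.45 log units; beyond the scatter), involves a 2-chlorophenyl, a different substitution pattern, and raised the number. A nitro brings more heavy atoms and two acceptors than a fluoro, so a somewhat larger effect than the fluoro step is plausible, but its direction cannot be read from these three compounds. A step of about a 1.0-fold lower number from compound 3 to compound 4 (0.02 log units; within the scatter) is therefore expected, likely within or just beyond the scatter. Compound 4 is estimated at 6000 nM, with a range from 2500 nM to 15000 nM.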

Compound 4, half-maximal inhibitory concentration: > 50000 nM
Compound 4 gave a limit, no number; the forecaster's own chance of this, stated with the estimate: 3%; middle value at least 8.3-fold (0.92 log units) from the limit.
By their numbers in this assay, from the lowest: compounds 3 and 1 (each within the scatter of the next); then compound 2. At a limit, above all of these: compound 4.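

In this assay, compound 4 gives a limit and not a number: the limit of > 50000 nM in this assay, at which 1 of the 4 values shown sits.

The fluoro step, a 1.2-fold lower number from compound 1 to compound 3 (0.07 log units; within the scatter), had made this place on the ring look tolerant, but the new result shows that it does not accept every group: nitro in place of fluoro gives an at least 8.0-fold higher number from compound 3 to compound 4 (0.90 log units; beyond the scatter), and nitro in place of hydrogen gives an at least 6.8-fold higher number from compound 1 to compound 4 (0.83 log units; beyond the scatter). For the compounds shown here, the comparison with the chloro compound, an at least 2.4-fold higher number from compound 2 to compound 4 (0.38 log units; beyond the scatter), shows that the 3-nitrophenyl group also moves the number further than the 2-chlorophenyl group, which until now gave the only step from compound 1 beyond the scatter.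

From the compounds shown here alone, the limit leaves the true size of these steps unknown, so it remains open how far compound 4 lies from the other three. With only fluoro and nitro at this place, it is also unclear whether an amine or a methoxy group there would stay close to compound 3 or move the number as far as the nitro does.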